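The compounds below may be only part of what the source reports. "The series", "measured", "known", "first", "only" and "open" are said of these compounds alone.

Series so far, measured in a functional assay on HUVEC cells (Homo sapiens) for antiproliferative activity, read by MTT assay, with a stated time of 24 h; a lower number here means a stronger inhibitor, a higher number a weaker inhibitor:
- Compound 1 `C=CCOc1ccc2c(=O)c(-c3cc(OC)c(OC)cc3OC)coc2c1`: > 10000 nM, a limit of the assay
- Compound 2 `COc1cc(OC)c(-c2coc3cc(OCc4ccccc4)ccc3c2=O)cc1OC`: 9750 nM

Among the measured compounds shown here, compound 2 holds the only actual number. The other reading is a limit: the limit of > 10000 nM in this assay, at which 1 of the 2 values shown sits.

The next compound is compound 3 `COc1cc(OC)c(-c2coc3cc(OCC(=O)c4cccc(C(F)(F)F)c4)ccc3c2=O)cc1OC`. Its change from compound 2 is (3-(trifluoromethyl)phenyl)carbonyl in place of phenyl on a saturated chain carbon bound to an oxygen on an aromatic ring. In words, (3-(trifluoromethyl)phenyl)carbonyl stands in place of phenyl, on a saturated chain carbon bound to an oxygen on an aromatic ring.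

For the measured compounds named here, only one measured step bears on this place: an at least 1.0-fold lower number from compound 1 to compound 2 (0.01 log units; that floor lies within the scatter). It exchanges vinyl for phenyl and gives only a floor for the size of the change. Going by the values given here, no measured step covers a carbonyl or a trifluoromethyl at this place, so the evidence for the new group is thin.

With compound 2 at 9750 nM and that single step as the guide, no shift beyond the scatter is expected in this assay. The estimated step is a 1.4-fold lower number from compound 2 to compound 3 (0.14 log units; within the scatter). For compound 3 the estimated value is 7000 nM, with an expected range from 2000 nM to 20000 nM.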

Compound 3, half-maximal inhibitory concentration: > 10000 nM
Compound 3: only a limit was reported; the forecaster's own chance of this, stated with the estimate: 35%; middle value at least 1.4-fold (0.15 log units) away from the limit.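

In this assay compound 3 gives > 10000 nM, which is a limit of the assay and not a number. As far as these compounds go, putting (3-(trifluoromethyl)phenyl)carbonyl in place of phenyl on a saturated chain carbon bound to an oxygen on an aromatic ring gives an at least 1.0-fold higher number from compound 2 to compound 3 (0.01 log units; that floor lies within the scatter), so this exchange, which brings in a carbonyl and a trifluoromethyl at once, shows no gain in this assay, and the true size of the step stays unknown past that floor. The step between compound 1 and compound 3 cannot be read, and the series now sits mostly at a single limit: the limit of > 10000 nM in this assay, at which 2 of the 3 values shown sit.

From the compounds shown here alone, the carbonyl and the trifluoromethyl enter together, so what each contributes alone remains open, as does the effect of the trifluoromethyl's place on the phenyl ring. Also open, going by these compounds, is whether an amine, a carboxylic acid or a longer chain at this place would give a reading clearly stronger than compound 2 at 9750 nM.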